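Swapping a chain nitrile for an amide on a shared core

A few compounds are considered here, and "the series" means these few. Any claim that something is new, unique, unknown or untested is made for them only; others in the source may bear on it.

Measured compounds:
Compound 1, `CCc1cc(C(C)=O)c(O)cc1OCCCCCCC#N`: 103%
Compound 2, `CSCc1cc(C(C)=O)c(O)cc1OCCCCCCC#N`: 97%
Compound 3, `C=CCc1cc(C(C)=O)c(O)cc1OCCCCCCC#N`: 97%

In an assay on isolated protein for inhibition of leukotriene B4 receptor 1 (Homo sapiens), tested at 10 uM (a higher number here means more inhibition at the concentration tested (going by the name of the read-out), a lower number less inhibition), compound 1 gives the highest of the three numbers, yet its steps to compound 2, a number 6 percentage points lower from compound 1 to compound 2 (within the scatter), and to compound 3, a number 6 percentage points lower from compound 1 to compound 3 (within the scatter), both stay within the scatter, as does no change at the digits printed from compound 2 to compound 3 (within the scatter). Compound 4, `CCc1cc(C(C)=O)c(O)cc1OCCCC(C)(C)C(N)=O`, differs from compound 1 by 1-carbamoyl-1-methylethyl in place of 3-cyanopropyl on a saturated chain carbon, three bonds along the chain from an oxygen on an aromatic ring. Going by the values given here, none of the measured steps touches this chain; all three alter the group on a saturated chain carbon bound to an aromatic carbon, so no step bears directly on the change. With the measured steps all within the scatter, compound 4 is expected to stay near compound 1, with the step of a number 18 percentage points lower from compound 1 to compound 4 (beyond the scatter) carrying wide uncertainty. Compound 4 is estimated at 85%, ranging from 45% to 105%.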

Compound 4, a percentage reported as inhibition, at one concentration (the size of the read-out at that concentration, not a potency): 92%
Beside the measured number, compound 4's estimate is 7 percentage points below it, and the stated range covers the measured number.
By their numbers in this assay, from the lowest: compounds 4, 2, 3 and 1 (each within the scatter of the next, the first and the last beyond it).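

Going by these compounds alone, this is the first change at the place three bonds along the chain from an oxygen on an aromatic ring, and in this assay putting 1-carbamoyl-1-methylethyl in place of 3-cyanopropyl gives a number 11 percentage points lower from compound 1 to compound 4 (beyond the scatter). The nitrile is therefore not required for a high reading, since compound 4 still gives 92%. Nothing available explains the step.

Compound 4 swaps the nitrile for an amide and also changes the chain, so the two changes cannot be separated. From the compounds shown here alone, how a carboxylic acid, an amine or a longer chain would read at this place remains open.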